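Removing an amino group from compound 2

This account rests on a few compounds, and the source may have more. Where it says the series, first, only, none or still open, it means among the compounds named here.

- Compound 1 `COc1cc(OC)c(/C=C/S(=O)(=O)Nc2cc([N+](=O)[O-])c(OC)c([N+](=O)[O-])c2)c(OC)c1`: 10000 nM
- Compound 2 `COc1cc(OC)c(/C=C/S(=O)(=O)Nc2cc(N)c(OC)c(N)c2)c(OC)c1`: 7500 nM
- Compound 3 `COc1cc(OC)c(/C=C/S(=O)(=O)Nc2ccc(OC)c(OC(=O)C(C)(C)C3=C(C)C(=O)C=C(C)C3=O)c2)c(OC)c1`: 8 nM

All three compounds have been tested in a functional assay on K562 cells (Homo sapiens) for cytotoxicity, read by trypan blue exclusion, with a stated time of 96 h; a lower number here means a stronger inhibitor, a higher number a weaker inhibitor. Compound 2 stands level with compound 1, since their two values lie within the scatter of each other. Compound 3 stands far apart from both, and its gap to compound 2 lies well beyond the scatter.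

Compound 4 `COc1cc(OC)c(/C=C/S(=O)(=O)Nc2ccc(OC)c(N)c2)c(OC)c1` has yet to be measured. It follows from compound 2 with hydrogen in place of amino on an aromatic carbon, ortho to a methoxy group: hydrogen in place of amino on an aromatic carbon. Compound 3, at 8 nM, also has hydrogen on that carbon, while compound 1 and compound 2 do not. Compound 3 differs from compound 2 in more than one place, however, so this comparison is only a loose guide.

The expected change is large and points toward a stronger inhibitor: a 190-fold lower number from compound 2 to compound 4 (2.27 log units; beyond the scatter). Compound 4 is estimated at 40 nM, with an expected range from 5 nM to 800 nM.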

Compound 4, half-maximal inhibitory concentration: 3 nM
Estimate against measurement, compound 4: 13-fold (1.12 log units) above; the measured number lies below the stated range.
By their numbers in this assay, from the lowest: compound 4; then compound 3; then compounds 2 and 1 (each within the scatter of the next).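

In this assay, hydrogen in place of amino on an aromatic carbon, ortho to a methoxy group, gives a 2500-fold lower number from compound 2 to compound 4 (3.40 log units; beyond the scatter). The earlier compounds shown here differed from one another in more than one place, so they could not tie a change of this size to this single carbon; this step shows that this one exchange is enough to produce it, with the second amino group, meta to this carbon, still in place in compound 4. No measurement shown here explains why the step is so large.

The compounds shown leave open how a methyl group or a fluorine atom on this carbon would compare with hydrogen. They also leave open whether exchanging the remaining amino group for hydrogen or an acetamide would change the number in this assay.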